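Working notes: shifting the bromine on compound 3

This account rests on a few compounds, and the source may have more. Where it says the series, first, only, none or still open, it means among the compounds named here.

In a functional assay on NCI-H1975 cells (Homo sapiens) for inhibition, read by MTT assay, with a stated time of 72 h (a higher number here means a weaker inhibitor, a lower number a stronger inhibitor), the measured compounds are:
compound 1 `O=C(CSc1nc(Nc2ccccc2)c2ccccc2n1)Nc1ccc(F)cc1` gives 16500 nM
compound 2 `O=C(CSc1nc(Nc2ccccc2)c2ccccc2n1)Nc1ccc([N+](=O)[O-])cc1` gives 13000 nM
compound 3 `C=CC(=O)Nc1cccc(NC(=O)CSc2nc(Nc3ccccc3Br)c3ccccc3n2)c1` gives 19300 nM

Compound 3 stands at the highest of the three numbers, but its gaps to compound 1 and to compound 2 are both within the scatter, so no ranking among the three is claimed.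

Compound 4 `C=CC(=O)Nc1cccc(NC(=O)CSc2nc(Nc3ccc(Br)cc3)c3ccccc3n2)c1` differs from compound 3 by 4-bromophenyl in place of 2-bromophenyl on a nitrogen on an aromatic ring. Among the compounds with values here, the only measured step, a 1.3-fold lower number from compound 1 to compound 2 (0.10 log units; within the scatter), concerns the other aromatic ring and was within the scatter; no measured step moves a substituent on the bromophenyl ring. The shift a 1.1-fold lower number from compound 3 to compound 4 (0.06 log units; within the scatter) is therefore expected to stay within the scatter. Compound 4 is estimated at 17000 nM, from 6000 nM to 50000 nM.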

Compound 4, half-maximal inhibitory concentration: 6280 nM
Compound 4: middle estimate off by 2.7-fold (0.43 log units), on the high side; the range from low to high includes it.
By their numbers in this assay, from the lowest: compound 4; then compounds 2, 1 and 3 (each within the scatter of the next).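

In this assay, 4-bromophenyl in place of 2-bromophenyl on the nitrogen gives a 3.1-fold lower number from compound 3 to compound 4 (0.49 log units; beyond the scatter) and so shows that this position responds to where the bromine sits. Within the data shown here, the only earlier step stayed within the scatter and concerned the other aromatic ring. No measured evidence accounts for the difference between these two compounds, which have the same atoms.

From the compounds shown here alone, it remains open whether the lower number depends on bromine itself. A chlorine, a methoxy group or an amine in place of the bromine of 4-bromophenyl would test this.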